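From 4-hydroxyphenyl to 4-methoxyphenyl in the series

The source may report more compounds than this note shows. Statements on the series, on what has been measured and on what is new or still open speak of the compounds shown alone.

Measured in a functional assay on the whole organism (strain albino) with Mus musculus as the target, with a stated time of 0.5 h; a lower number here means that less compound is needed, a higher number that more compound is needed for the effect:
- compound 1 `COc1ccc(C2CC(Nc3nc4ccc([N+](=O)[O-])cc4s3)=NN2C(C)=O)cc1` gives 149 umol/kg
- compound 2 `COc1ccc(C2CC(Nc3nc4ccc(Cl)cc4s3)=NN2C(C)=O)cc1O` gives 132 umol/kg
- compound 3 `CC(=O)N1N=C(Nc2nc3ccc(Cl)cc3s2)CC1c1ccc(O)cc1` gives 107 umol/kg

Compound 3 at 107 umol/kg lies within the scatter of both other compounds. The next compound, compound 4 `COc1ccc(C2CC(Nc3nc4ccc(Cl)cc4s3)=NN2C(C)=O)cc1`, places methyl in place of hydrogen on an oxygen on an aromatic ring and so turns 4-hydroxyphenyl into 4-methoxyphenyl. Within the data shown here, the one measured step that bears on this, a 1.2-fold lower number from compound 2 to compound 3 (0.09 log units; within the scatter), changes the same aromatic group and stays within the scatter. No step beyond the scatter is therefore expected in this assay, and the expected step is a 1.1-fold higher number from compound 3 to compound 4 (0.05 log units; within the scatter) overall. Compound 4 is estimated at 120 umol/kg in the middle, with an expected range from 70 umol/kg to 205 umol/kg as the limits of the estimate.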

Compound 4, dose for half-maximal effect: 97.3 umol/kg
Compound 4: the middle estimate sits 1.2-fold (0.09 log units) above what was measured, within the range that was stated.
By their numbers in this assay, from the lowest: compounds 4, 3, 2 and 1 (each within the scatter of the next).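

In this assay, methyl in place of hydrogen on the oxygen stays within the scatter (a 1.1-fold lower number from compound 3 to compound 4 (0.04 log units; within the scatter)), so the free hydroxy on the aromatic ring is not needed for a number in this range. Hydrogen in place of hydroxy on an aromatic carbon (a 1.4-fold lower number from compound 2 to compound 4 (0.13 log units; within the scatter)) and chloro in place of nitro on an aromatic carbon (a 1.5-fold lower number from compound 1 to compound 4 (0.19 log units; within the scatter)) also stay within the scatter. Going by these compounds, whether an amine or a carboxylic acid on the aromatic ring, or a longer chain on the oxygen, would give a step beyond the scatter remains open. Nothing available explains why these steps are so small.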